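A few compounds are considered here, and "the series" means these few. Any claim that something is new, unique, unknown or untested is made for them only; others in the source may bear on it.

In a toxicity assay on CCRF-CEM cells (Homo sapiens) for cytotoxicity (a higher number here means that more compound is tolerated, a lower number that less compound is tolerated), compound 1 (`CC(C)=CCc1cccc2c1nc(-c1c(F)cccc1F)n2Cc1c(F)cccc1F`) gives 28.3 uM and compound 2 (`O=Cc1cccc2c1nc(-c1c(F)cccc1F)n2Cc1c(F)cccc1F`) gives 0.82 uM as the lower of the two numbers. Compound 3 (`NCc1cccc2c1nc(-c1c(F)cccc1F)n2Cc1c(F)cccc1F`) has aminomethyl in place of formyl on an aromatic carbon. For the measured compounds named here, the one measured step at this place is a 35-fold lower number from compound 1 to compound 2 (1.54 log units; beyond the scatter) and it involves a different incoming group, so it bounds the size only loosely. A moderate rise in this assay is expected, toward the number of compound 1 without reaching it. The expected change is a 4.9-fold higher number from compound 2 to compound 3 (0.69 log units; beyond the scatter) and this remains an estimate. Compound 3 is estimated at 4 uM with an expected range from 1 uM to 20 uM in this reading.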

Compound 3, half-maximal toxic concentration: 49.3 uM
Compound 3: the middle estimate sits 12-fold (1.09 log units) below what was measured; measured number outside the range, above it.
By their numbers in this assay, from the lowest: compound 2; then compounds 1 and 3 (each within the scatter of the next).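

In this assay the low number at this position now stands with formyl alone, since aminomethyl in its place gives a 60-fold higher number from compound 2 to compound 3 (1.78 log units; beyond the scatter) in a large step. Aminomethyl and 3-methylbut-2-en-1-yl cannot be told apart here (a 1.7-fold higher number from compound 1 to compound 3 (0.24 log units; within the scatter)), so two quite different groups share the tolerated level and only formyl departs from it. Nothing available explains the formyl result.

Going by these compounds, it remains open whether a hydroxymethyl group or a carboxylic acid at this position would read like compound 3 or like compound 2.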